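Methoxy in Place of Fluoro: Compound 2 to Compound 4

This account rests on a few compounds, and the source may have more. Where it says the series, first, only, none or still open, it means among the compounds named here.

Measured in a functional assay on MGC-803 cells (Homo sapiens) for inhibition, read by sulforhodamine B assay; a lower number here means a stronger inhibitor, a higher number a weaker inhibitor:
compound 1 `O=C1C(Nc2ccccc2F)=CC(=O)c2c1nc1n2[C@H]2OC[C@@H](O)[C@H]2OC1` gives 2000 nM
compound 2 `O=C1C=C(Nc2cccc(F)c2)C(=O)c2c1nc1n2[C@H]2OC[C@@H](O)[C@H]2OC1` gives 2180 nM
compound 3 `O=C1C(N2CCCCC2)=CC(=O)c2c1nc1n2[C@H]2OC[C@@H](O)[C@H]2OC1` reaches only a limit, > 4000 nM

Compound 2 and compound 1 sit within the scatter of each other, so neither can be placed ahead of the other. Compound 3 stands at the limit of > 4000 nM in this assay, at which 1 of the 3 values shown sits. Compound 4 `COc1cccc(NC2=CC(=O)c3nc4n(c3C2=O)[C@H]2OC[C@@H](O)[C@H]2OC4)c1` differs from compound 2 by methoxy in place of fluoro on an aromatic carbon. Among the measured compounds shown here, the only measured step, an at least 2.0-fold higher number from compound 1 to compound 3 (0.30 log units; that floor lies within the scatter), exchanges the whole (2-fluorophenyl)amino group and says nothing about fluoro against methoxy on the phenyl ring. For the measured compounds named here, with no closer step available, compound 4 is expected to stay near compound 2, with a step of a 1.0-fold higher number from compound 2 to compound 4 (0.00 log units; within the scatter) that lies within the scatter, so the estimate for compound 4 is 2200 nM, between 900 nM and 5000 nM.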

Compound 4, half-maximal inhibitory concentration: 1780 nM
Estimate against measurement, compound 4: 1.2-fold (0.09 log units) above; measured number inside the range.
By their numbers in this assay, from the lowest: compounds 4, 1 and 2 (each within the scatter of the next). At a limit, above all of these: compound 3.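

In this assay, among the compounds shown here, the exchange on the phenyl ring gives a 1.2-fold lower number from compound 2 to compound 4 (0.09 log units; within the scatter) and so offers the first direct reading of a substituent at this place: 3-fluorophenyl and 3-methoxyphenyl cannot be told apart. Methoxy carries a hydrogen-bond acceptor that fluoro lacks, yet the step stays within the scatter. Nothing measured here bears on the reason for this result. The compounds shown leave open whether an amine or a carboxylic acid in this place would give a step beyond the scatter. Going by these compounds, whether methoxy would read the same on the phenyl ring of compound 1 also remains open.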